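Working notes: cyano to trifluoromethoxy, cytotoxicity outlook

This account rests on a few compounds, and the source may have more. Where it says the series, first, only, none or still open, it means among the compounds named here.

Compound 1 `CC1CCN(C2CCN(S(=O)(=O)c3cn(C)cn3)CC2)CC1` was run in an ADME assay on HCT-116 cells (Homo sapiens) for cytotoxicity, read by CellTiter-Glo, with a stated time of 72 h; a lower number here means a stronger inhibitor, a higher number a weaker inhibitor; compound 1 gives only a limit there, > 10000 nM. Compound 2 `CC1CCN(C2CCN(S(=O)(=O)c3ccc(C#N)cc3)CC2)CC1` likewise gives only a limit in this assay, > 5000 nM. The step that the two limits leave unreadable from compound 1 to compound 2 is thus unreadable, since both values sit at limits (the limit of > 10000 nM in this assay, at which 1 of the 2 values shown sits, (the limit of > 5000 nM in this assay, at which 1 of the 2 values shown sits)). Compound 2 therefore stands at a limit, with no number to place it against. Compound 3 `CC1CCN(C2CCN(S(=O)(=O)c3ccc(OC(F)(F)F)cc3)CC2)CC1` differs from compound 2 by trifluoromethoxy in place of cyano on an aromatic carbon. Going by the values given here, no measured step speaks to this change, and with both measured compounds at limits no shift beyond the scatter is anticipated; a limit is the likely outcome again. Compound 3 is expected near 8000 nM (2500 nM to 30000 nM), the estimated step being a step that the limit leaves unreadable from compound 2 to compound 3.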

Compound 3, half-maximal inhibitory concentration: > 5000 nM
Compound 3 gave a limit, no number; the forecaster's own chance of this, stated with the estimate: 75%; the middle value is on the limit's open side.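

In this assay compound 2 and compound 3 both stand at limits, so the step between them cannot be read. The compounds shown leave open whether trifluoromethoxy and cyano differ at all in this read-out.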